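Isopropyl on the carbamoyl nitrogen of compound 3

The source may report more compounds than this note shows. Statements on the series, on what has been measured and on what is new or still open speak of the compounds shown alone.

Measured compounds:
compound 1 `CC(C)NC(=O)N1CCN(C(=S)SCc2cn(Cc3ccccc3F)nn2)CC1` – 7130 nM
compound 2 `CC(C)NC(=O)N1CCN(C(=S)SCc2cn(Cc3ccc(F)cc3)nn2)CC1` – 5970 nM
compound 3 `Cc1ccc(Cn2cc(CSC(=S)N3CCN(C(N)=O)CC3)nn2)cc1` – > 128000 nM

In a functional assay on SMMC-7721 cells (Homo sapiens) for cytotoxicity, read by MTT assay, with a stated time of 72 h (on this read-out lower numbers stand for stronger inhibition and higher numbers for weaker inhibition), compound 1 gives 7130 nM. Compound 2 gives 5970 nM in this assay, and the step of a 1.2-fold lower number from compound 1 to compound 2 (0.08 log units; within the scatter) shows that exchanging one fluorophenyl for the other leaves the read-out essentially unchanged. Compound 3 stands apart: in this assay it is reported only as a limit, > 128000 nM, so no number is known for it, only that it lies beyond the range of the measurement (the limit of > 128000 nM in this assay, at which 1 of the 3 values shown sits).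

Compound 4 `Cc1ccc(Cn2cc(CSC(=S)N3CCN(C(=O)NC(C)C)CC3)nn2)cc1` differs from compound 3 by a single change: isopropyl in place of hydrogen on an amide-type nitrogen, that is, amino becomes isopropylamino and carbamoyl becomes isopropylcarbamoyl. Within the data shown here, no measured step covers this particular exchange. Among the measured compounds shown here, the only step in hand, a 1.2-fold lower number from compound 1 to compound 2 (0.08 log units; within the scatter), concerns a different part of the molecule and is within the scatter, so it says nothing about the carbamoyl nitrogen. What can be said is that compound 1 and compound 2, which both carry the isopropylcarbamoyl group that compound 4 also carries, gave numbers in the low micromolar region, whereas compound 3 with the bare carbamoyl group gave only a limit.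

On that basis compound 4 is expected to move toward a measurable value, with an estimated step of an at least 6.4-fold lower number from compound 3 to compound 4 (0.80 log units; beyond the scatter). The estimate for compound 4 is 20000 nM, with a range from 5000 nM to 128000 nM.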

Compound 4, half-maximal inhibitory concentration: > 128000 nM
Compound 4: a limit, no number; the forecaster's own chance of this, stated with the estimate: 30%; middle value at least 6.4-fold (0.80 log units) away from the limit.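

Isopropyl on the amide-type nitrogen does not by itself bring the compound into a measurable range in this assay, so the isopropylcarbamoyl group shared with compound 1 and compound 2 is not enough for a measurable value. With that group held constant, methyl in place of fluoro on an aromatic carbon gives an at least 21-fold higher number from compound 2 to compound 4 (1.33 log units; beyond the scatter), and 4-methylphenyl in place of 2-fluorophenyl gives an at least 17-fold higher number from compound 1 to compound 4 (1.25 log units; beyond the scatter), which makes the aromatic substituent a large factor among these compounds, a point the exchange of one fluorophenyl for the other could not show. The step from compound 3 to compound 4 cannot be read, because both compounds are reported only as a limit and neither gives a number: the limit of > 128000 nM in this assay, at which 2 of the 4 values shown sit.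

As far as these compounds go, the effect of isopropyl when fluoro stands on the aromatic carbon remains open, as the bare carbamoyl group appears here only with the methyl substituent. From the compounds shown here alone, it is also open whether chloro or methoxy on that aromatic carbon, or a longer chain such as butyl on the amide-type nitrogen, would give a measurable value.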